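This account rests on a few compounds, and the source may have more. Where it says the series, first, only, none or still open, it means among the compounds named here.

In a functional assay on MCF7 cells (Homo sapiens) for inhibition, read by sulforhodamine B assay, with a stated time of 48 h (on this read-out lower numbers stand for stronger inhibition of growth and higher numbers for weaker inhibition of growth), compound 1 `Cc1ccc(NC2=NCCO2)cc1` gives 27000 nM. Compound 2 `Cc1ccc(NC2=NCCO2)cc1C` carries methyl in place of hydrogen on an aromatic carbon, and this change made a 4.7-fold lower number from compound 1 to compound 2 (0.68 log units; beyond the scatter). In this assay compound 2 gives 5700 nM. Compound 3 `Cc1ccc(NC(=O)NC(=O)CCl)cc1` rests on a different core; the difference between the two cores is not broken down here. In this assay compound 3 gives 7500 nM. Compound 4 `Cc1ccc(NC(=O)NC(=O)CCl)cc1C` differs from compound 3 by methyl in place of hydrogen on an aromatic carbon. This is the same kind of change as that from compound 1 to compound 2, though the place is not identical: in compound 2 the entering methyl sits meta to a group of 6 heavy atoms, whereas in compound 4 it sits meta to a group of 8 heavy atoms. Compound 4 is expected to show a 2.5-fold lower number from compound 3 to compound 4 (0.40 log units; beyond the scatter), because the same kind of change gave a 4.7-fold lower number from compound 1 to compound 2 (0.68 log units; beyond the scatter) on the other core, with the step held somewhat smaller as the cores are not the same. In this assay compound 4 is estimated at 3000 nM, with an expected range from 1200 nM to 7500 nM.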

Compound 4, concentration for 50% growth inhibition: 5500 nM
Beside the measured number, compound 4's estimate is 1.8-fold (0.26 log units) below it; the measured number falls inside the stated range.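

In this assay methyl in place of hydrogen on an aromatic carbon gave a 1.4-fold lower number from compound 3 to compound 4 (0.13 log units; within the scatter) and so did not repeat the size of the step seen on the core of compound 1. The two steps differ: the same change on two cores in this assay, a 4.7-fold lower number (0.68 log units; beyond the scatter) from compound 1 to compound 2 and a 1.4-fold lower number (0.13 log units; within the scatter) from compound 3 to compound 4, 3.5-fold (0.54 log units) apart, beyond the scatter of two such steps. On these two pairs, then, the size of this change did not carry from one core to the other, but two pairs do not show what sets the gap or how the change would behave on a further core.

Open, on these data alone, is how an ethyl group, a methoxy group or an amine on the same aromatic carbon would behave on either core. Also open, as far as these compounds go, is whether the gap between the two cores would persist with those groups.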